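This account rests on a few compounds, and the source may have more. Where it says the series, first, only, none or still open, it means among the compounds named here.

Working notes on the series in an ADME assay on microsomes from liver (Mus musculus) for metabolic stability, with a stated time of 30 min; a lower number here means that less of the compound is left, a higher number that more of the compound is left.

Three compounds have numbers. Compound 1 `Cn1c(C(F)(F)F)ccc(NCc2cc3cc(Cl)ccc3[nH]c2=O)c1=O` gives 67% in this assay. Compound 2 `COc1cccc(NCc2cc3cc(Cl)ccc3[nH]c2=O)c1` gives 19%. Compound 3 `CCn1cccc(NCc2cc3cc(Cl)ccc3[nH]c2=O)c1=O` gives 7%, the lowest of the three; the nearest number is that of compound 2, which lies higher by a gap beyond the scatter, and the furthest is that of compound 1, higher still. No pair among these three differs in only one place, so no single-point step within the measured set can be read.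

Compound 4 `O=c1[nH]c2ccc(Cl)cc2cc1CNc1cccn(C2CC2)c1=O` has not yet been measured. It differs from compound 3 in one place: cyclopropyl in place of ethyl on an aromatic nitrogen. Nothing in the measured set tests this particular change, so the expectation rests on the starting point alone. A step of small size, in either direction, most likely within the scatter, is expected in this assay.

For compound 4 the estimate in this assay is 12%, with a range from 3% to 30%, which would mean a step of a number 5 percentage points higher from compound 3 to compound 4 (within the scatter).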

Compound 4, percent of the compound remaining in the Mus musculus assay: 7%
Beside the measured number, compound 4's estimate is 5 percentage points above it; measured number inside the range.
By their numbers in the Mus musculus assay, from the lowest: compounds 3 and 4 (each within the scatter of the next); then compound 2; then compound 1.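

In the Mus musculus assay, cyclopropyl in place of ethyl on an aromatic nitrogen gives no separation between the two compounds (no change at the digits printed from compound 3 to compound 4 (within the scatter)). Going by these compounds alone, this is the first single-place step, and at this position it leaves the number at the low end of the measured set. In a physicochemical assay for solubility (on this read-out higher numbers stand for higher solubility and lower numbers for lower solubility), compound 3 gives 10000 nM and compound 4 gives 56000 nM, so the same change does register on solubility, even though it does not register on the percent remaining: the measured solubility of compound 3, 10000 nM, and of compound 4, 56000 nM, a 5.6-fold higher number (0.75 log units; beyond the scatter).

Compound 1 differs from compound 3 in more than one place, so its higher number in the Mus musculus assay cannot be assigned to any single group. As far as these compounds go, how a longer chain, an amine or a carboxylic acid on this nitrogen would read in either assay remains open.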